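From 3-bromophenyl to 4-fluorophenyl: a cell tolerance question

The source may report more compounds than this note shows. Statements on the series, on what has been measured and on what is new or still open speak of the compounds shown alone.

Compound 1 `CC/C(=C\c1ccc(Cl)cc1)C(C)=O` gives 136000 nM
Compound 2 `CC/C(=C\c1ccc(Cl)cc1)C(=O)/C=C/c1ccc([N+](=O)[O-])cc1` gives 36000 nM
Compound 3 `COc1ccc(/C=C(\C)C(=O)/C=C/c2cccc(Br)c2)cc1` gives 153000 nM

All three values come from an ADME assay on Vero cells (Chlorocebus sabaeus) for cytotoxicity, read by MTT assay, with a stated time of 72 h (a lower number here means that less compound is tolerated, a higher number that more compound is tolerated), and can be compared directly. Compound 3 at 153000 nM cannot be told apart from compound 1 at 136000 nM in this measurement, as the two lie within the usual scatter of each other. Compound 2 at 36000 nM has a lower number than compound 3, and that gap lies beyond the scatter.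

Compound 4 `COc1ccc(/C=C(\C)C(=O)/C=C/c2ccc(F)cc2)cc1` has not yet been measured in this assay and keeps the rest of compound 3. Among the compounds with values here, it carries 4-fluorophenyl in place of 3-bromophenyl on a double-bonded chain carbon bound to a double-bonded chain carbon as its only change.

Within the data shown here, no two measured compounds differ in just one place, so the data offer no direct measure of this swap. Only a loose guide remains, and compound 2 at 36000 nM shows that a lower number is possible among these compounds. The expected change is a 1.4-fold lower number from compound 3 to compound 4 (0.14 log units; within the scatter) and so no step beyond the scatter, with a slight lean towards a lower number. The estimated value for compound 4 is 110000 nM with an expected range of 40000 nM to 260000 nM.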

Compound 4, half-maximal cytotoxic concentration: 68100 nM
Compound 4: the middle estimate sits 1.6-fold (0.21 log units) above what was measured, and the stated range covers the measured number.
By their numbers in this assay, from the lowest: compounds 2, 4, 1 and 3 (each within the scatter of the next, the first and the last beyond it).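

In this assay, within the data shown here, placing 4-fluorophenyl in place of 3-bromophenyl on a double-bonded chain carbon bound to a double-bonded chain carbon gives a 2.2-fold lower number from compound 3 to compound 4 (0.35 log units; beyond the scatter), the first direct reading of a single change in this small set. It shows that this position is not silent: cell tolerance can shift here even though the entering and leaving groups match in their computed counts of heavy atoms, hydrogen-bond donors and acceptors, and in having no net charge. No measurement of any property of these groups accompanies the result, so the reason for the step remains unknown.

This single swap alters both the halogen and its place on the ring, and without 3-fluorophenyl or 4-bromophenyl at this position, the compounds shown cannot say which of the two alterations carries the step. Also open, as far as these compounds go, is how a group of a different kind, such as an amine or a carboxylic acid on this ring, would affect tolerance, and whether the same swap would give a similar step on a different core.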